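This account rests on a few compounds, and the source may have more. Where it says the series, first, only, none or still open, it means among the compounds named here.

Of the compounds shown here, three built on one shared core have been tested in a functional assay on B16-F10 cells (Mus musculus) for cytotoxicity; a lower number here means a stronger inhibitor, a higher number a weaker inhibitor. Compound 1 `O=c1oc2ccccc2c2nc3c(ccc4cc[nH]c43)c(-c3c(Cl)cccc3Cl)c12` gives 70700 nM, compound 2 `O=c1oc2ccccc2c2nc3c(ccc4cc[nH]c43)c(-c3ccc([N+](=O)[O-])cc3)c12` gives 70700 nM and compound 3 `O=c1oc2ccccc2c2nc3c(ccc4cc[nH]c43)c(-c3ccc(Cl)cc3Cl)c12` gives 70700 nM. Compound 3 therefore stands level with the other two, and none of the three can be called stronger or weaker.

The next compound, compound 4 `COc1ccc(-c2c3ccc4cc[nH]c4c3nc3c2c(=O)oc2ccccc23)cc1`, keeps the shared core and differs from compound 3 at one place: 4-methoxyphenyl in place of 2,4-dichlorophenyl on an aromatic carbon. A 4-methoxyphenyl group takes the place of the 2,4-dichlorophenyl group on an aromatic carbon, opposite the ring nitrogen.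

Among the compounds with values here, three measured steps bear on this change, and each swaps the group at this same place: no change at the digits printed from compound 1 to compound 3 (within the scatter), no change at the digits printed from compound 1 to compound 2 (within the scatter) and no change at the digits printed from compound 2 to compound 3 (within the scatter). Across these three compounds, then, changing this group has produced no step beyond the scatter in this assay, and none is expected here in either direction. Within the data shown here, still, no measured compound carries a 4-methoxyphenyl group, so the expectation is an extrapolation and the range has to stay wide. The estimated step is a 1.1-fold lower number from compound 3 to compound 4 (0.06 log units; within the scatter). For compound 4 the estimated value is 62000 nM, with an expected range of 22000 nM to 80000 nM.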

Compound 4, half-maximal inhibitory concentration: 70700 nM
The estimate for compound 4 lay 1.1-fold (0.06 log units) below the measured number; low and high end bracket the measured number.
By their numbers in this assay, from the lowest: compounds 1, 2, 3 and 4 (each within the scatter of the next).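

In this assay, the new compound shows no change at the digits printed from compound 3 to compound 4 (within the scatter) and no change at the digits printed from compound 2 to compound 4 (within the scatter) and also no change at the digits printed from compound 1 to compound 4 (within the scatter) in this series. Until now, the group on this aromatic carbon, opposite the ring nitrogen, had been a dichlorophenyl or a 4-nitrophenyl; the 4-methoxyphenyl group has no chlorine and no nitro group, yet it adds a fourth compound with no separation from the others, so this wider set of substituted phenyl groups still gives no step beyond the scatter. No evidence is available that explains this flat result at this position.

From the compounds shown here alone, all four compounds carry a substituted phenyl ring at this place, so it remains open whether a group of another kind there, such as an amine, a carboxylic acid or a longer alkyl chain, would shift the number in either direction. The shared core is also the same in all four compounds, so these results say nothing about what a change elsewhere on it would do.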